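This account rests on a few compounds, and the source may have more. Where it says the series, first, only, none or still open, it means among the compounds named here.

Measured in an ADME assay on Huh7.5.1 cells (Homo sapiens) for cytotoxicity, read by ATP content, with a stated time of 48 h; on this read-out lower numbers stand for higher toxicity in this test and higher numbers for lower toxicity in this test:
compound 1 `Cc1ccccc1-c1nc(CN2CCC(C(=O)NCCN3C[C@H](C)C[C@H](C)C3)CC2)c(C)o1`: 24400 nM
compound 2 `Cc1ccccc1-c1nc(CN2CCC(C(=O)NCCCCN3C[C@H](C)C[C@H](C)C3)CC2)c(C)o1`: 23100 nM
compound 3 `Cc1oc(-c2c(Cl)cccc2C(F)(F)F)nc1CN1CCC(C(=O)NCCCN2C[C@H](C)C[C@H](C)C2)CC1`: 12000 nM

Compound 3 holds the lowest of the three numbers in this assay; compound 2 sits within the scatter of it, compound 1 beyond it. Compound 4 `Cc1ccc(-c2nc(CN3CCC(C(=O)NCCCN4C[C@H](C)C[C@H](C)C4)CC3)c(C)o2)c(C)c1` differs from compound 3 by 2,4-dimethylphenyl in place of 2-chloro-6-(trifluoromethyl)phenyl on an aromatic carbon. Among the compounds with values here, the only step measured so far, a 1.1-fold lower number from compound 1 to compound 2 (0.02 log units; within the scatter), changes the chain and says nothing about this aryl exchange. Compounds 1 and 2, which carry a methyl-bearing phenyl at the same position, both give higher numbers than compound 3, so compound 4 is expected to move back toward them: a 1.7-fold higher number from compound 3 to compound 4 (0.22 log units; within the scatter) is the expected step. Compound 4 is estimated at 20000 nM, with a range of 9000 nM to 42000 nM.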

Compound 4, half-maximal cytotoxic concentration: 4110 nM
Compound 4: middle estimate off by 4.9-fold (0.69 log units), on the high side, and the stated range ends above it.
By their numbers in this assay, from the lowest: compound 4; then compounds 3, 2 and 1 (each within the scatter of the next, the first and the last beyond it).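

In this assay, the exchange of 2-chloro-6-(trifluoromethyl)phenyl for 2,4-dimethylphenyl gives a 2.9-fold lower number from compound 3 to compound 4 (0.47 log units; beyond the scatter), so a change of aryl group at this position moves the read-out beyond the scatter. The chain step, a 1.1-fold lower number from compound 1 to compound 2 (0.02 log units; within the scatter), showed no such movement, though it involved a different place on the molecule. Nothing at hand explains the aryl step.

As far as these compounds go, the exchange alters all the ring substituents at once, so which of them carries the step remains open. A plain phenyl or a 2-chlorophenyl at this position would help separate their contributions.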